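Where a Benzoyl Group Sits on Compound 1

This account rests on a few compounds, and the source may have more. Where it says the series, first, only, none or still open, it means among the compounds named here.

Among the measured compounds shown here, in a functional assay on the whole organism with Homo sapiens as the target (on this read-out lower numbers stand for an effect already at smaller amounts and higher numbers for an effect only at larger amounts of compound), compound 1 `CC(O)(C(=O)Nc1ccccc1Cl)C(F)(F)F` gives 5400 nM, the lower of the two numbers known so far. Compound 3 `CC(O)(C(=O)Nc1ccc(C(=O)c2ccccc2)cc1Cl)C(F)(F)F` keeps the core of compound 1 and changes one place: benzoyl in place of hydrogen on an aromatic carbon. This is benzoyl in place of hydrogen on an aromatic carbon, meta to a chloro group and para to a large group.

For the measured compounds named here, the only guide is compound 2 `CC(O)(C(=O)Nc1cccc(C(=O)c2ccccc2)c1Cl)C(F)(F)F`, which carries benzoyl at a different place and gives 11000 nM. Its measured step is modest: a 2.0-fold higher number from compound 1 to compound 2 (0.31 log units; beyond the scatter). From the compounds shown here alone, a single step at another place says little about this new one, so the direction remains open, with only a tentative lean towards a lower number in this assay. The expected change is a 3.6-fold lower number from compound 1 to compound 3 (0.56 log units; beyond the scatter). Compound 3 is estimated at 1500 nM, with an expected range from 200 nM to 10000 nM.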

Compound 3, half-maximal effective concentration: 30000 nM
Compound 3: middle estimate off by 20-fold (1.30 log units), on the low side; measured number outside the range, above it.
By their numbers in this assay, from the lowest: compound 1; then compound 2; then compound 3.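

In this assay, placing benzoyl on this aromatic carbon, meta to a chloro group and para to a large group, brings a 5.6-fold higher number from compound 1 to compound 3 (0.74 log units; beyond the scatter) and so does not give the lower number the earlier data leaned towards. The step runs in the same direction as a 2.0-fold higher number from compound 1 to compound 2 (0.31 log units; beyond the scatter), so in both placements shown, adding benzoyl to compound 1 gives a higher number, and no compound here goes against that. No measurement here accounts for this rise at either position.

From the compounds shown here alone, whether a methyl group, an amine or a carboxylic acid at this same carbon would also raise the number remains open. How benzoyl would behave on the remaining carbons of that ring is equally unsettled.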